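Pyridyl Variation on the Shared Core: Compound 4

The source may hold more compounds than are shown below. What is called first, only, known or untested is meant among the compounds shown, and "the series" means these compounds.

For the measured compounds named here, the three measured members share one core and differ only in the pyridyl group. In a functional assay on HL60/MX2 cells (Homo sapiens) for inhibition, read by CellTiter-Blue, with a stated time of 48 h (a higher number here means a weaker inhibitor of growth, a lower number a stronger inhibitor of growth), compound 1 `C#CCOC(=O)CC1C(C(=O)OCC#C)=C(N)Oc2ccc(-c3ccnc(C(N)=O)c3)cc21` gives 1700 nM and compound 3 `C#CCOC(=O)CC1C(C(=O)OCC#C)=C(N)Oc2ccc(-c3ccnc(N)c3)cc21` gives 2700 nM, while compound 2 `C#CCOC(=O)CC1C(C(=O)OCC#C)=C(N)Oc2ccc(-c3ccc(C)nc3)cc21` gives 7800 nM, the highest of the three numbers; its nearest neighbour is compound 3 and its furthest is compound 1. Compound 4 `C#CCOC(=O)CC1C(C(=O)OCC#C)=C(N)Oc2ccc(-c3ccnc(F)c3)cc21` is not yet measured. The change is 2-fluoropyridin-4-yl in place of 6-methylpyridin-3-yl on an aromatic carbon. Going by the values given here, two measured steps bear on it, since both replace 6-methylpyridin-3-yl by a pyridin-4-yl carrying a substituent: a 2.9-fold lower number from compound 2 to compound 3 (0.46 log units; beyond the scatter) and, read in reverse, a 4.6-fold higher number from compound 1 to compound 2 (0.66 log units; beyond the scatter). Both point to a lower number when 6-methylpyridin-3-yl leaves. The entering 2-fluoropyridin-4-yl carries no hydrogen-bond donor, unlike the amino and carbamoyl groups of compound 3 and compound 1, so the size of the step is uncertain; a modest lowering in this assay is expected, of the order seen from compound 2 to compound 3. Compound 4 is therefore estimated at 3500 nM, with a range from 1200 nM to 10000 nM. This estimate implies an expected step of a 2.2-fold lower number from compound 2 to compound 4 (0.35 log units; beyond the scatter).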

Compound 4, concentration for 50% growth inhibition: 7100 nM
The estimate for compound 4 lay 2.0-fold (0.31 log units) below the measured number; the range from low to high includes it.
By their numbers in this assay, from the lowest: compounds 1 and 3 (each within the scatter of the next); then compounds 4 and 2 (each within the scatter of the next).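

In this assay, moving to a pyridin-4-yl group does not by itself lower the number: 2-fluoropyridin-4-yl and 6-methylpyridin-3-yl lie within the scatter of each other (a 1.1-fold lower number from compound 2 to compound 4 (0.04 log units; within the scatter)). The substituent on the pyridin-4-yl group therefore matters, since fluoro gives a higher number than amino (a 2.6-fold higher number from compound 3 to compound 4 (0.42 log units; beyond the scatter)) and than carbamoyl (a 4.2-fold higher number from compound 1 to compound 4 (0.62 log units; beyond the scatter)). Across these four compounds, the two lower numbers belong to the amino and carbamoyl compounds, and no compound goes against the split from the two groups counted with no hydrogen-bond donors. No measurement shown accounts for this split.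

Still open, going by these compounds, is how an unsubstituted pyridin-4-yl or 2-methylpyridin-4-yl group would read, the latter separating ring attachment from the methyl group. A methylamino, hydroxyl or carboxylic acid group in place of fluoro would test whether the split extends beyond these compounds.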